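Amide substituent series: aryl exchange on the carbonyl carbon

A few compounds are considered here, and "the series" means these few. Any claim that something is new, unique, unknown or untested is made for them only; others in the source may bear on it.

Measured so far in this series:
compound 1, `CC(C)OC(=O)C1=CN(C(=O)C2CCCCC2)CC(C)(C)c2cc(C#N)[nH]c21`, gives 124%
compound 2, `CC(C)OC(=O)C1=CN(C(=O)c2cccc(C(F)(F)F)c2)CC(C)(C)c2cc(C#N)[nH]c21`, gives 94%

Both numbers come from an assay on HEK293 cells for agonist activity at Bile acid receptor (Homo sapiens), read by a luciferase reporter; a higher number here means a larger maximal response, a lower number a smaller maximal response. Compound 2 stands lowest of the two values seen; its nearest neighbour is compound 1, whose value lies higher by a margin beyond the scatter. Within the data shown here, the only measured step is a number 30 percentage points lower from compound 1 to compound 2 (beyond the scatter), brought about by 3-(trifluoromethyl)phenyl in place of cyclohexyl on a carbonyl carbon.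

Compound 3, `CC(C)OC(=O)C1=CN(C(=O)c2ccc(C#N)cc2)CC(C)(C)c2cc(C#N)[nH]c21`, has not yet been measured. It differs from compound 2 in one place:
4-cyanophenyl in place of 3-(trifluoromethyl)phenyl on a carbonyl carbon

Among the measured compounds shown here, no measured step exchanges one aryl group for another on this carbonyl carbon; the one step seen swaps a saturated ring for an aryl group, so it bears only loosely on the present change. With nothing pointing in either direction, compound 3 is expected to give about 95% in this assay, with a range from 70% to 125%. The expected step, a number 1 percentage points higher from compound 2 to compound 3 (within the scatter), would lie within the usual scatter, and the measurement will tell.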

Compound 3, largest response reached (reported as efficacy), in percent of the reference or control that the assay uses: 116%
Compound 3: middle estimate off by 21 percentage points, on the low side, within the range that was stated.
By their numbers in this assay, from the lowest: compound 2; then compounds 3 and 1 (each within the scatter of the next).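

In this assay, among these compounds, exchanging one aryl group for another on this carbonyl carbon is not neutral: a number 22 percentage points higher from compound 2 to compound 3 (beyond the scatter), so the choice of aryl group matters here, which the single step from a saturated ring could not show. An aryl group on this carbonyl carbon does not in itself bring the smaller maximal response seen for compound 2, since a number 8 percentage points lower from compound 1 to compound 3 (within the scatter), leaving 4-cyanophenyl and cyclohexyl indistinguishable in this read-out. No measurement on hand explains the difference between 4-cyanophenyl and 3-(trifluoromethyl)phenyl.

The two aryl groups differ both in the substituent and in where it sits on the ring, so the compounds shown cannot separate these two changes. Also open, from the compounds shown here alone, is how an unsubstituted phenyl group, a phenyl group carrying a carboxylic acid, or a straight butyl chain on this carbonyl carbon would compare with 4-cyanophenyl and cyclohexyl in this assay.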